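A few compounds are considered here, and "the series" means these few. Any claim that something is new, unique, unknown or untested is made for them only; others in the source may bear on it.

Measured compounds:
Compound 1, `CC(=O)N1CCc2ccccc2C1CC(c1ccccc1)c1ccccc1`, in an assay on isolated protein for inhibition of melatonin receptor type 1A (Homo sapiens) (on this read-out lower numbers stand for stronger inhibition and higher numbers for weaker inhibition), gives > 1000 nM.
Compound 2, `COc1cccc2c1CCN(C(C)=O)C2CC(c1ccccc1)c1ccccc1`, in this assay gives > 1000 nM.

Compound 1 stands at a limit only: its value in this assay is a limit of the assay and not a measured number. Compound 2 likewise stands at a limit in this assay. The step that the two limits leave unreadable from compound 1 to compound 2 therefore cannot be read, because the limit of > 1000 nM in this assay, at which 2 of the 2 values shown sit, places both values at the same limit, so neither its size nor its direction is known.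

Compound 3, `COc1ccc2c(c1)CCN(C(C)=O)C2CC(c1ccccc1)c1ccccc1`, differs from compound 1 by methoxy in place of hydrogen on an aromatic carbon. Going by the values given here, the one measured step of the same kind, from compound 1 to compound 2, has no readable size, so nothing measured here tells how large a step to expect in this assay, in either direction. With both known compounds at the limit, the expectation for compound 3 is that it also stays weak in this assay, most likely again reported only as a limit. The estimate for compound 3 is 3000 nM, with a range from 800 nM to 30000 nM. The step that the limit leaves unreadable from compound 1 to compound 3 is thus expected to be small or not readable beyond the scatter.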

Compound 3, half-maximal inhibitory concentration: > 1000 nM
Compound 3: a limit, no number; the forecaster's own chance of this, stated with the estimate: 80%; the middle value does not contradict the limit.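

Going by these compounds alone, compound 3 stands at a limit and not at a number, as do compound 1 and compound 2, so no step among them can be read in this assay: the limit of > 1000 nM in this assay, at which 3 of the 3 values shown sit. Left open is how strongly each of the three compounds acts in this assay, and whether methoxy in place of hydrogen on an aromatic carbon changes that in either direction.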